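The source may hold more compounds than are shown below. What is called first, only, known or untested is meant among the compounds shown, and "the series" means these compounds.

Of the compounds shown here, two built on one shared core have been measured so far: compound 1 `COc1cc(N2C(=O)C(O)C2c2ccc(SC)cc2)cc(OC)c1OC` and compound 2 `CCOc1ccc(C2C(Oc3ccccc3)C(=O)N2c2cc(OC)c(OC)c(OC)c2)cc1`. In a functional assay on HL-60 cells (Homo sapiens) for inhibition, read by resazurin assay, with a stated time of 72 h (a lower number here means a stronger inhibitor, a higher number a weaker inhibitor), compound 1 gives 15 nM. In this assay compound 2 gives 494 nM, the highest of the two numbers recorded, and its gap from compound 1 lies well beyond the scatter. The two compounds differ in more than one place, so their values show only that gap, not what any single change contributes.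

Compound 3 `CCOc1ccc(C2C(O)C(=O)N2c2cc(OC)c(OC)c(OC)c2)cc1` is not yet measured. It keeps the rest of compound 2 and differs from it in one place: hydrogen in place of phenyl on an oxygen on a saturated carbon. This leaves compound 3 carrying a hydroxy group at the place where compound 1 also carries one, though the two still differ elsewhere. Going by the values given here, no step between measured compounds is available to calibrate the change, so its size can only be anticipated. Compound 3 is expected to give a clearly lower number in this assay than compound 2, with the step of an 8.2-fold lower number from compound 2 to compound 3 (0.92 log units; beyond the scatter) reaching beyond the scatter. In this assay compound 3 is estimated at 60 nM, within a range from 15 nM to 250 nM.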

Compound 3, half-maximal inhibitory concentration: 11 nM
Compound 3: middle estimate off by 5.5-fold (0.74 log units), on the high side, outside the stated range (below it).
By their numbers in this assay, from the lowest: compounds 3 and 1 (each within the scatter of the next); then compound 2.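

In this assay, the single change from phenoxy to hydroxy on the saturated carbon gives a 45-fold lower number from compound 2 to compound 3 (1.65 log units; beyond the scatter), so this position, which until now had only been part of a gap between compounds differing in more than one place, is shown on its own to matter strongly to the number recorded. With hydroxy held at this position, the change at the other end of the molecule, ethoxy in place of methylsulfanyl on an aromatic carbon, gives a 1.4-fold lower number from compound 1 to compound 3 (0.13 log units; within the scatter), and so these two groups are not told apart in this measurement while hydroxy is present. Nothing at hand bears on why the phenoxy to hydroxy change has so large a step.

The compounds shown hold only these two groups on this oxygen, so they leave open where a methoxy, a benzyloxy or an acetoxy group would fall, and whether an amine or a fluorine could stand in for the hydroxy group. They also leave open whether the methylsulfanyl and ethoxy groups would remain indistinguishable with phenoxy at this position, since that pairing rests on hydroxy alone.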